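Compound 2 to compound 4: one methoxy fewer

This account rests on a few compounds, and the source may have more. Where it says the series, first, only, none or still open, it means among the compounds named here.

In a functional assay on CHO-TAX 5-6 cells (Cricetulus griseus) for antiproliferative activity, read by sulforhodamine B assay, with a stated time of 48 h (a lower number here means a stronger inhibitor, a higher number a weaker inhibitor), compound 2 (`COc1cc(NS(=O)(=O)c2ccc(N3CCNC3=O)cc2)cc(OC)c1OC`) gives 170 nM. Compound 1 (`CCc1cccc(NS(=O)(=O)c2ccc(N3CCNC3=O)cc2)c1`) gives 140 nM, and the two values lie within the scatter of each other. Compound 3 (`Cc1ccc(C)c(NS(=O)(=O)c2ccc(N3CCNC3=O)cc2)c1`) gives 54 nM, a lower number than that of compound 2, with a gap beyond the scatter. Among the measured compounds shown here, compound 2 therefore sits with compound 1 at the upper end of the numbers so far, and compound 3 sits at the lower end.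

Compound 4 (`COc1cc(NS(=O)(=O)c2ccc(N3CCNC3=O)cc2)cc(OC)c1`) differs from compound 2 in one place: hydrogen in place of methoxy on an aromatic carbon. The change is hydrogen in place of methoxy on an aromatic carbon, ortho to two methoxy groups and para to a large group.

For the measured compounds named here, only one measured step connects two compounds: a 2.6-fold lower number from compound 1 to compound 3 (0.41 log units; beyond the scatter). Going by the values given here, that step is modest and concerns a different change, and no measured pair shows the loss of a methoxy. It offers a rough scale for step size but no direction for this change. A small step, not clearly beyond the scatter, is therefore expected. The estimated change is a 1.1-fold lower number from compound 2 to compound 4 (0.05 log units; within the scatter). For compound 4 the expected value is 150 nM, with an estimated range from 60 nM to 400 nM.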

Compound 4, half-maximal inhibitory concentration: 220 nM
The estimate for compound 4 lay 1.5-fold (0.17 log units) below the measured number; the range from low to high includes it.
By their numbers in this assay, from the lowest: compound 3; then compounds 1, 2 and 4 (each within the scatter of the next).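

Hydrogen can stand in place of the methoxy ortho to two methoxy groups and para to a large group without separating the two compounds in this assay: the step is a 1.3-fold higher number from compound 2 to compound 4 (0.11 log units; within the scatter) and so gives compound 2 and compound 4 no order. Among the compounds shown here, this is the first measured pair to address a methoxy on this ring, and it shows that the loss of this one group, with its 2 heavy atoms and 1 hydrogen-bond acceptor, does not by itself produce a step that can be read beyond the scatter. The data hold no independent measurement that could explain this result, so the finding stands as an observation on this single pair.

Going by these compounds, the pair tests only hydrogen at this carbon, so it remains open whether a hydroxyl, an amine, a carboxylic acid or an ethoxy there would stay within the scatter of compound 2. On these data alone, it also remains open whether either of the two methoxy groups left in compound 4 can be replaced by hydrogen in the same way, since a single step says nothing about those positions.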